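The compounds below may be only part of what the source reports. "The series", "measured", "known", "first", "only" and "open" are said of these compounds alone.

Measured compounds in a functional assay on HCC1937 cells (Homo sapiens) for antiproliferative activity, read by CCK-8 assay, with a stated time of 72 h; on this read-out higher numbers stand for weaker inhibition and lower numbers for stronger inhibition:
compound 1, `O=C(Nc1cccc(-c2oc3cc(-c4ccc(F)cc4)ccc3c(=O)c2O)c1)c1ccccc1F`, gives 10800 nM;
compound 2, `O=C(Nc1cccc(-c2oc3cc(-c4ccc(F)cc4)ccc3c(=O)c2O)c1)c1cc(F)cc(F)c1`, gives 2070 nM.

Going by the values given here, compound 2 holds the lowest of the two numbers so far in this assay; its nearest neighbour is compound 1, which sits higher by the step of a 5.2-fold lower number from compound 1 to compound 2 (0.72 log units; beyond the scatter), the sole measured step in the set and the only one that changes the ring on the carbonyl carbon of the amide.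

Compound 3, `O=C(Nc1cccc(-c2oc3cc(-c4ccc(F)cc4)ccc3c(=O)c2O)c1)c1ccc([N+](=O)[O-])cc1`, is not yet measured. It differs from compound 2 as follows: 4-nitrophenyl in place of 3,5-difluorophenyl on a carbonyl carbon. Among the compounds with values here, no measured pair exchanges a fluorinated ring for a nitrated one, so the one measured step bears on it only in showing that the ring on this carbonyl carbon can move the number in this assay by a modest amount. Within the data shown here, with no closer precedent, the expectation for compound 3 in this assay is a number near that of compound 2, leaning somewhat higher, with the step of a 1.7-fold higher number from compound 2 to compound 3 (0.23 log units; within the scatter) expected to stay inside the usual scatter. The estimate for compound 3 in this assay is 3500 nM, with a range from 1000 nM to 12000 nM.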

Compound 3, half-maximal inhibitory concentration: 5640 nM
Beside the measured number, compound 3's estimate is 1.6-fold (0.21 log units) below it, and the stated range covers the measured number.
By their numbers in this assay, from the lowest: compound 2; then compounds 3 and 1 (each within the scatter of the next).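

In this assay, the ring on the carbonyl carbon can now be compared with a ring carrying no fluorine: a 2.7-fold higher number from compound 2 to compound 3 (0.44 log units; beyond the scatter), so the number responds to the exchange of 3,5-difluorophenyl for 4-nitrophenyl as well as to the change between the two fluorinated rings. The second new comparison, a 1.9-fold lower number from compound 1 to compound 3 (0.28 log units; within the scatter), does not separate these two compounds, which leaves compound 2 alone among the three, with steps beyond the scatter to both of the others. Nothing at hand indicates what lies behind these differences.

The compounds shown leave open whether a plain phenyl, 4-aminophenyl or 4-carboxyphenyl ring on this carbonyl carbon would fall with compound 2 or with the other two compounds. They also leave open whether a saturated ring such as cyclohexyl, or a pyridine ring, could hold this position and bring the number in this assay under that of compound 2 at 2070 nM.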